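Compound 4: methoxymethyl on the ring nitrogen of compound 3

A few compounds are considered here, and "the series" means these few. Any claim that something is new, unique, unknown or untested is made for them only; others in the source may bear on it.

Compound 1 `COc1cc(CC(O)(COCc2ccccc2)COCc2ccccc2)nc(OC)n1` is a limit in a functional assay on MCF7 cells (Homo sapiens) for antiproliferative activity, read by MTT assay, with a stated time of 72 h (a higher number here means a weaker inhibitor, a lower number a stronger inhibitor), giving > 100000 nM. Compound 2 `COc1nc(CC(O)(COCc2ccccc2)COCc2ccccc2)c(C)c(OC)n1` gives 4200 nM in this assay, so an at least 23-fold lower number from compound 1 to compound 2 (1.37 log units; beyond the scatter) through methyl in place of hydrogen on an aromatic carbon. Compound 3 `O=c1cc(CC(O)(COCc2ccccc2)COCc2ccccc2)[nH]c(=O)[nH]1` is likewise a limit in this assay, with > 100000 nM, and the step that the two limits leave unreadable from compound 1 to compound 3. Compound 3 therefore stands at the limit of > 100000 nM in this assay, at which 2 of the 3 values shown sit, with no number of its own.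

Compound 4 `COCn1c(CC(O)(COCc2ccccc2)COCc2ccccc2)cc(=O)[nH]c1=O` carries methoxymethyl in place of hydrogen on an aromatic nitrogen, the methoxymethyl sitting ortho to a large group and two atoms from the ring nitrogen. Among the measured compounds shown here, no measured step touches that nitrogen. For the measured compounds named here, the only step that moves a number at all, an at least 23-fold lower number from compound 1 to compound 2 (1.37 log units; beyond the scatter), concerns a different core and an aromatic carbon, and the step that the two limits leave unreadable from compound 1 to compound 3 is unreadable. A small group added to the shared core of compound 3 is thus expected to shift the number by an at least 1.6-fold lower number from compound 3 to compound 4 (0.22 log units; that floor lies within the scatter), with wide uncertainty. Compound 4 is accordingly estimated at 60000 nM in this assay, within 10000 nM to 300000 nM.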

Compound 4, half-maximal inhibitory concentration: > 100000 nM
Compound 4: no number, only a limit (the forecaster's own chance of this, stated with the estimate: 45%); middle value at least 1.6-fold (0.22 log units) from the limit.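

In this assay compound 4 gives > 100000 nM, a limit; compound 3 is also only a limit, so no step between the two can be read: the limit of > 100000 nM in this assay, at which 3 of the 4 values shown sit.

As far as these compounds go, what methoxymethyl on the aromatic nitrogen does to the number remains open, since neither compound has a number of its own.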